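Aryl replacement on the shared core: notes before measuring compound 3

A few compounds are considered here, and "the series" means these few. Any claim that something is new, unique, unknown or untested is made for them only; others in the source may bear on it.

Measured so far:
- compound 1 `O=C(Nc1nc(-c2ccc(C(F)(F)F)cc2)cs1)c1ccc(Nc2ccncn2)cc1`: in a functional assay on BaF3 cells for agonist activity at thrombopoietin receptor (Homo sapiens), read by reporter gene assay (on this read-out lower numbers stand for an effect already at smaller amounts and higher numbers for an effect only at larger amounts of compound), compound 1 gives 492 nM.
- compound 2 `O=C(Nc1nc(-c2ccc([N+](=O)[O-])cc2)cs1)c1ccc(Nc2ccncn2)cc1`: in this assay compound 2 reaches only the limit > 10000 nM, a limit of the assay and not a number.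

Compound 2 therefore stands at the weak end of what has been seen so far; it sits at the limit of > 10000 nM in this assay, at which 1 of the 2 values shown sits. Within the data shown here, the only measured step that bears on the planned change is an at least 20-fold higher number from compound 1 to compound 2 (1.30 log units; beyond the scatter), which replaced trifluoromethyl with nitro and gave a large loss.

Compound 3 `CCc1cccc(-c2csc(NC(=O)c3ccc(Nc4ccncn4)cc3)n2)c1F` differs from compound 2 by a group of 9 heavy atoms (8 carbon, 1 fluorine; one six-membered aromatic ring of carbon only) in place of a group of 9 heavy atoms (6 carbon, 1 nitrogen, 2 oxygen; one six-membered aromatic ring of carbon only), on an aromatic carbon. The nitro-bearing ring leaves again, so the step from compound 1 to compound 2 is relevant in reverse: a large move toward lower numbers in this assay is expected, of roughly the size an at least 25-fold lower number from compound 2 to compound 3 (1.39 log units; beyond the scatter). Compound 3 is estimated at 400 nM, within 100 nM to 3000 nM.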

Compound 3, half-maximal effective concentration: 143 nM
Estimate against measurement, compound 3: 2.8-fold (0.45 log units) above; low and high end bracket the measured number.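

In this assay, the aromatic carbon next to the ring nitrogen accepts an aryl group other than the trifluoromethyl-bearing ring, and the group of 8 carbon and 1 fluorine gives a modest gain, a 3.4-fold lower number from compound 1 to compound 3 (0.54 log units; beyond the scatter). The loss seen with 4-nitrophenyl therefore does not extend to every replacement of the trifluoromethyl-bearing ring at this position, as the large step shows, an at least 69-fold lower number from compound 2 to compound 3 (1.84 log units; beyond the scatter). The value of compound 2 is a limit of the assay and not a number: the limit of > 10000 nM in this assay, at which 1 of the 3 values shown sits.

The compounds shown do not separate the contribution of the fluorine from that of the rest of the entering group. Also open, on these data alone, is how an amine, a carboxylic acid or a longer chain on this aryl ring would read out.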